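The compounds below may be only part of what the source reports. "The series", "measured", "known", "first", "only" and "open" are said of these compounds alone.

In a functional assay on CHO cells for antagonist activity at sphingosine 1-phosphate receptor 2 (Homo sapiens), read by fluorescence and calcium flux, with a stated time of 3 min (on this read-out lower numbers stand for stronger inhibition and higher numbers for weaker inhibition), compound 1 `Cc1cc(CNC(=O)Nc2cc(OCC(O)CO)nc(C(F)(F)F)c2)nnc1-c1cn(C)nc1C(F)(F)F` gives only a limit of the assay, > 6610000 nM. Compound 2 `Cc1cc(CNC(=O)Nc2cc(OCCO)nc(C(F)(F)F)c2)nnc1-c1cn(C)nc1C(F)(F)F` gives 348000 nM in this assay. The change between them is an at least 18-fold lower number from compound 1 to compound 2 (1.27 log units; beyond the scatter). Going by the values given here, compound 2 therefore holds the only real number in this assay so far. The value of compound 1 is the limit of > 6610000 nM in this assay, at which 1 of the 2 values shown sits, a limit rather than a number.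

Compound 3 `Cc1cc(CNC(=O)Nc2cc(C(F)(F)F)nc(OCCO)c2C)nnc1-c1cn(C)nc1C(F)(F)F` is not yet measured. It differs from compound 2 by methyl in place of hydrogen on an aromatic carbon, a methyl in place of hydrogen on an aromatic carbon ortho to the 2-hydroxyethoxy group. Among the compounds with values here, the single measured step concerns a saturated chain carbon, not an aromatic one, so it gives no direct guide to this change. No step beyond the scatter is therefore expected in this assay, and the step is estimated as a 1.0-fold higher number from compound 2 to compound 3 (0.00 log units; within the scatter). Compound 3 is expected to give about 350000 nM, between 100000 nM and 1500000 nM.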

Compound 3, half-maximal inhibitory concentration: 84000 nM
Compound 3: middle estimate off by 4.2-fold (0.62 log units), on the high side, and the stated range ends above it.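

In this assay, adding a single methyl to the aromatic carbon ortho to the 2-hydroxyethoxy group and para to the trifluoromethyl group gives a 4.1-fold lower number from compound 2 to compound 3 (0.62 log units; beyond the scatter). Going by these compounds alone, the earlier step lay on the saturated chain, so this is the first sign that the read-out also responds to a change on the aromatic ring, here a change of just 1 heavy atom. Within the data shown here, nothing measured so far explains why this methyl lowers the number.

The compounds shown leave open whether a different group on this carbon, such as an ethyl, a chlorine or a methoxy group, would lower the number further or raise it again. They also leave open whether the same methyl would lower the number with the chain of compound 1 in place of the 2-hydroxyethoxy group.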